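Same sulfonyl change, second core: expected cytotoxicity

This account rests on a few compounds, and the source may have more. Where it says the series, first, only, none or still open, it means among the compounds named here.

Measured so far in an ADME assay on HEK293 cells (Homo sapiens) for cytotoxicity, read by resazurin assay, with a stated time of 48 h; on this read-out lower numbers stand for higher toxicity in this test and higher numbers for lower toxicity in this test:
compound 1 `Cc1ccccc1S(=O)(=O)Nc1ccc2oc(-c3ccccc3)nc2c1` gives 57000 nM
compound 2 `COc1cccc(S(=O)(=O)Nc2ccc3oc(-c4ccccc4)nc3c2)c1` gives 63000 nM
compound 3 `COc1cccc(S(=O)(=O)Nc2ccc(-c3nc4ccccc4o3)cc2)c1` reaches only a limit of the test, > 100000 nM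

Compounds 1 and 2 share one core and differ only on the sulfonyl sulfur, (2-methylphenyl in place of 3-methoxyphenyl on a sulfonyl sulfur). That change produced a 1.1-fold lower number from compound 2 to compound 1 (0.04 log units; within the scatter). Compound 3 has a different core; how the two cores differ is not broken down here. Compound 4 `Cc1ccccc1S(=O)(=O)Nc1ccc(-c2nc3ccccc3o2)cc1`, not yet measured, is compound 3 with the same change, (2-methylphenyl in place of 3-methoxyphenyl on a sulfonyl sulfur), at the same place. Because a 1.1-fold lower number from compound 2 to compound 1 (0.04 log units; within the scatter) stayed within the scatter, a similar outcome is expected here. For compound 4 in this assay the expected step is a number no higher from compound 3 to compound 4 (the limit leaves the size open). Compound 4 is estimated at 100000 nM, between 50000 nM and 200000 nM. As compound 3 sits at the limit of > 100000 nM in this assay, at which 1 of the 3 values shown sits, compound 4 may also return only a limit.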

Compound 4, half-maximal cytotoxic concentration: > 100000 nM
Compound 4 gave a limit, no number; the forecaster's own chance of this, stated with the estimate: 65%; the middle value sits exactly at the limit.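

Compound 3 and compound 4 each return only a limit in this assay, and no step between them can be read: the limit of > 100000 nM in this assay, at which 2 of the 4 values shown sit.

The compounds shown leave open whether 2-methylphenyl in place of 3-methoxyphenyl on a sulfonyl sulfur changes the cytotoxicity number on this core at all.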